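Removing the Benzyl Ester: Compound 3 to Compound 4

The source may report more compounds than this note shows. Statements on the series, on what has been measured and on what is new or still open speak of the compounds shown alone.

Measured compounds:
compound 1, `N=C(N)NCCC[C@H](NC(=O)CN(c1nc(Cl)nc2[nH]cnc12)C1CC1)C(=O)O`, 27.6%
compound 2, `NC(=O)C[C@H](NC(=O)CN(c1nc(Cl)nc2[nH]cnc12)C1CC1)C(=O)O`, 20.1%
compound 3, `CC(C)C[C@H](NC(=O)CN(c1nc(Cl)nc2[nH]cnc12)C1CC1)C(=O)OCc1ccccc1`, 15.2%

The three measured compounds share one core and differ at the amino-acid part. In a functional assay on the whole organism (Tail, strain ICR) with Mus musculus as the target, in the tail flick test, with a stated time of 90 min, at a dose of 25 umol/kg by the oral route (on this read-out lower numbers stand for a weaker effect and higher numbers for a stronger effect at the one dose given), compound 1 gives 27.6%, compound 2 gives 20.1% and compound 3 gives 15.2%. Compound 3 stands lowest of the three numbers; the gap to compound 2 lies within the scatter, whereas the gap to compound 1 lies beyond it. Among the compounds with values here, the single step between compounds differing in one place, a number 7.5 percentage points lower from compound 1 to compound 2 (within the scatter), concerns the side chain and not the position that changes here.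

Compound 4, `CC(C)C[C@H](NC(=O)CN(c1nc(Cl)nc2[nH]cnc12)C1CC1)C(=O)O`, is compound 3 with hydrogen in place of benzyl on an oxygen next to a carbonyl group. Within the data shown here, no measured step bears on this change, so there is nothing to set its size from. Compounds 1 and 2 both carry the carboxy group that enters in compound 4, and both lie at or above compound 3 in this assay, which is the only hint the data give. On that basis compound 4 is expected to give 19%, in the range 8% to 31%. The expected step is a number 3.8 percentage points higher from compound 3 to compound 4 (within the scatter), a change not judged to exceed the scatter with any confidence.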

Compound 4, a percentage reported as activity, at one dose (the size of the read-out at that dose, not a potency): 27%
The estimate for compound 4 lay 8 percentage points below the measured number; the range from low to high includes it.
By their numbers in this assay, from the lowest: compounds 3, 2, 4 and 1 (each within the scatter of the next, the first and the last beyond it).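

Once the benzyl on the oxygen next to a carbonyl group gives way to hydrogen, this assay records a number 11.8 percentage points higher from compound 3 to compound 4 (beyond the scatter), the first step at this position and one that clears the scatter, although only modestly. With the carboxy group in place, the side chain shows no change beyond the scatter: isopropyl in place of carbamoyl gives a number 6.9 percentage points higher from compound 2 to compound 4 (within the scatter), and the group of 3 heavy atoms in place of the group of 6 heavy atoms gives a number 0.6 percentage points lower from compound 1 to compound 4 (within the scatter), so the benzyloxycarbonyl to carboxy change is the only one among these steps to exceed the scatter. The data offer no measurement that would explain this step.

On these data alone, the benzyl ester appears here with only one side chain, so it remains open whether the same step would appear with the carbamoyl side chain or with the side chain of compound 1. As far as these compounds go, it also remains open whether a methyl ester or a primary amide at this place would read like the benzyl ester or like the carboxylic acid.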